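Naphthol in Place of Chlorophenyl on the Shared Core

A few compounds are considered here, and "the series" means these few. Any claim that something is new, unique, unknown or untested is made for them only; others in the source may bear on it.

Compound 3 `N#CC1=C(N)N(c2ccc(S(N)(=O)=O)cc2)C2=C(CCCC2)C1c1ccccc1Cl` gives 0% in a functional assay on Ehrlich cells (Mus musculus) for cytotoxicity, read by trypan blue exclusion, with a stated time of 2 h, tested at 25 ug/mL (on this read-out lower numbers stand for a weaker effect and higher numbers for a stronger effect at the one concentration tested), the lowest of the three numbers. Compound 1 `N#CC1=C(N)N(c2ccc(S(N)(=O)=O)cc2)C2=C(CCCC2)C1c1ccccc1` gives 10%, and the step of a number 10 percentage points lower from compound 1 to compound 3 (within the scatter) stays within the scatter. Compound 2 `COc1ccc(C2C(C#N)=C(N)N(c3ccc(S(N)(=O)=O)cc3)C3=C2CCCC3)cc1` gives 90%, and the step of a number 90 percentage points lower from compound 2 to compound 3 (beyond the scatter) is large. Compound 4 `N#CC1=C(N)N(c2ccc(S(N)(=O)=O)cc2)C2=C(CCCC2)C1c1c(O)ccc2ccccc12` differs from compound 3 by 2-hydroxynaphthalen-1-yl in place of 2-chlorophenyl on a saturated ring carbon. For the measured compounds named here, the steps that bear on this are a number 80 percentage points higher from compound 1 to compound 2 (beyond the scatter), where a methoxy raised the number strongly, and a number 90 percentage points lower from compound 2 to compound 3 (beyond the scatter). The entering group brings an oxygen again, though as a hydroxy on a naphthalene rather than a methoxy, so a rise is expected but with wide uncertainty: the step of a number 40 percentage points higher from compound 3 to compound 4 (beyond the scatter) is what the estimate means. For compound 4 the estimated value is 40%, ranging from 5% to 85%.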

Compound 4, a percentage reported as activity, at one concentration (the size of the read-out at that concentration, not a potency): 5%
Beside the measured number, compound 4's estimate is 35 percentage points above it, and the stated range covers the measured number.
By their numbers in this assay, from the lowest: compounds 3, 4 and 1 (each within the scatter of the next); then compound 2.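

In this assay, the oxygen of a hydroxy group on a naphthalene does not restore the high number seen with 4-methoxyphenyl: the change gives a number 85 percentage points lower from compound 2 to compound 4 (beyond the scatter) at this saturated ring carbon. The same group gives a number 5 percentage points higher from compound 3 to compound 4 (within the scatter) and a number 5 percentage points lower from compound 1 to compound 4 (within the scatter) here, so compound 4 sits with the two low compounds, and only compound 2 stands apart. Nothing measured here explains this result. As far as these compounds go, whether 4-hydroxyphenyl or 4-aminophenyl at this carbon would keep the high number of compound 2 remains open.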